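This account rests on a few compounds, and the source may have more. Where it says the series, first, only, none or still open, it means among the compounds named here.

Measured so far in a functional assay on the whole organism for inhibition, with Scenedesmus acutus as the target; on this read-out higher numbers stand for weaker inhibition and lower numbers for stronger inhibition:
compound 1 `CCOC(=O)c1cc(N2C(=O)C3=C(CCCC3)C2=O)ccc1Cl`: 1910 nM
compound 2 `CCCCOC(=O)c1cc(N2C(=O)C3=C(CCCC3)C2=O)ccc1Cl`: 6310 nM

Compound 2 has the higher of the two numbers, which makes it the weaker inhibitor of the pair. Compound 3 `CCCCCCCCOC(=O)c1cc(N2C(=O)C3=C(CCCC3)C2=O)ccc1Cl` differs from it by one change: butyl in place of hydrogen on a saturated chain carbon, four bonds along the chain from an oxygen next to a carbonyl group. Going by the values given here, only one measured step bears on this, a lengthening of the same chain: a 3.3-fold higher number from compound 1 to compound 2 (0.52 log units; beyond the scatter). A further lengthening is therefore expected to raise the number again in this assay, by a similar or somewhat larger amount, though one step alone fixes no trend. The expected change is a 2.9-fold higher number from compound 2 to compound 3 (0.46 log units; beyond the scatter). The estimated value for compound 3 is 18000 nM, with an expected range of 6500 nM to 60000 nM.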

Compound 3, half-maximal inhibitory concentration: > 100000 nM
Compound 3 gave a limit, no number (the forecaster's own chance of this, stated with the estimate: 10%); at least 5.5-fold (0.74 log units) between middle value and limit.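

In this assay compound 3 gives a limit, not a number: > 100000 nM. Butyl in place of hydrogen at this place produces an at least 15-fold higher number from compound 2 to compound 3 (1.19 log units; beyond the scatter), and hexyl in place of hydrogen, counted from the shorter chain, produces an at least 52-fold higher number from compound 1 to compound 3 (1.71 log units; beyond the scatter). Lengthening this chain can therefore cost far more inhibition than the modest earlier step showed, and the full size of the loss stays hidden behind the limit.

The compounds shown leave open how a shorter methyl chain would compare with the ethyl of compound 1. They also leave open whether a carboxylic acid here would keep any inhibition.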